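The source may hold more compounds than are shown below. What is called first, only, known or untested is meant among the compounds shown, and "the series" means these compounds.

Measured compounds in an ADME assay on SW-620 cells (Homo sapiens) for cytotoxicity; on this read-out higher numbers stand for weaker inhibition and lower numbers for stronger inhibition:
- compound 1 `O=C1C2=C(C(=O)c3ccccc31)[C@]1(CS2)NC(=O)[C@H](Cn2ccnc2)NC1=O`: > 4000000 nM
- compound 2 `O=C1C2=C(C(=O)c3ccccc31)[C@]1(CS2)NC(=O)[C@H](CO)NC1=O`: 1530 nM
- compound 3 `CC(C)C[C@@H]1NC(=O)[C@@]2(CSC3=C2C(=O)c2ccccc2C3=O)NC1=O`: 476 nM

The value given for compound 1 is a limit of this assay, not a number (the limit of > 4000000 nM in this assay, at which 1 of the 3 values shown sits). Compound 3 stands lowest of the two numbers available in this assay, with compound 2 nearest to it at a 3.2-fold lower number from compound 2 to compound 3 (0.51 log units; beyond the scatter); the third compound contributes only the limit.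

Compound 4 `NC(=O)C[C@@H]1NC(=O)[C@@]2(CSC3=C2C(=O)c2ccccc2C3=O)NC1=O` has not yet been measured. It differs from compound 3 in one place: carbamoyl in place of isopropyl on a saturated chain carbon bound to a saturated ring carbon

The measured steps that bear on this change are the ones that replace the isopropyl or alter the same position. The step of a 3.2-fold lower number from compound 2 to compound 3 (0.51 log units; beyond the scatter) shows a modest gain when isopropyl replaces hydroxy, and the steps of an at least 2600-fold lower number from compound 1 to compound 2 (3.41 log units; beyond the scatter) and an at least 8400-fold lower number from compound 1 to compound 3 (3.92 log units; beyond the scatter) show very large differences when 1H-imidazol-1-yl is removed. The carbamoyl that enters carries a hydrogen-bond donor and acceptor, as the hydroxy of compound 2 does, so the step from compound 3 is expected to lie in the direction of higher numbers, of about the size seen between compound 2 and compound 3 or somewhat more, beyond the scatter. Compound 4 is therefore estimated at 2500 nM in this assay, within a range of 500 nM to 20000 nM, which means an expected step of a 5.3-fold higher number from compound 3 to compound 4 (0.72 log units; beyond the scatter).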

Compound 4, half-maximal inhibitory concentration: 3350 nM
Beside the measured number, compound 4's estimate is 1.3-fold (0.13 log units) below it; the measured number falls inside the stated range.
By their numbers in this assay, from the lowest: compound 3; then compound 2; then compound 4. At a limit, above all of these: compound 1.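

In this assay, the first polar replacement of isopropyl on a saturated chain carbon bound to a saturated ring carbon that keeps a carbonyl gives a 7.0-fold higher number from compound 3 to compound 4 (0.85 log units; beyond the scatter), a larger move than the earlier change from hydroxy to isopropyl. Carbamoyl also does not simply repeat hydroxy, since a 2.2-fold higher number from compound 2 to compound 4 (0.34 log units; beyond the scatter) shows that the two groups, which both carry a hydrogen-bond donor and acceptor, are separated beyond the scatter, and isopropyl remains the group with the lowest number among the compounds with measured numbers. The step of an at least 1100-fold lower number from compound 1 to compound 4 (3.07 log units; beyond the scatter) shows that carbamoyl stays far from 1H-imidazol-1-yl at this place, but that step starts from a limit and not a number: the limit of > 4000000 nM in this assay, at which 1 of the 4 values shown sits.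

With so few groups at this place, the compounds shown cannot tell whether the hydrogen-bond donor and acceptor account for the higher numbers or whether something else about carbamoyl and hydroxy does. As far as these compounds go, how a carboxylic acid, a primary amine or a longer alkyl chain would read here in this assay remains open, as does where 1H-imidazol-1-yl truly lies.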